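Swapping the amide aryl group on a phosphodiesterase inhibitor

This account rests on a few compounds, and the source may have more. Where it says the series, first, only, none or still open, it means among the compounds named here.

Measured compounds:
compound 1 `COc1ccc(C(=O)Nc2ccccc2O)cc1OC1CCCC1`: 1300 nM
compound 2 `COc1ccc(C(=O)Nc2cnccn2)cc1OC1CCCC1`: 250 nM

Two compounds share one core and differ only in the group on the amide-type nitrogen. In an assay on isolated protein for inhibition of phosphodiesterase 4A (Sus scrofa) (a higher number here means a weaker inhibitor, a lower number a stronger inhibitor), compound 1 gives 1300 nM, while compound 2 gives 250 nM, the lowest of the two numbers; the step of a 5.2-fold lower number from compound 1 to compound 2 (0.72 log units; beyond the scatter) shows that changing this group matters. Compound 3 `COc1ccc(C(=O)Nc2ccncc2Cl)cc1OC1CCCC1` carries the change (3-chloropyridin-4-yl in place of pyrazin-2-yl on an amide-type nitrogen). For the measured compounds named here, only the step from compound 1 to compound 2 bears on it, and it was modest. Compound 3 is therefore expected at 80 nM (range 15 nM to 400 nM). This estimate means a step of a 3.1-fold lower number from compound 2 to compound 3 (0.49 log units; beyond the scatter).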

Compound 3, half-maximal inhibitory concentration: 16 nM
Estimate against measurement, compound 3: 5.0-fold (0.70 log units) above; the range from low to high includes it.
By their numbers in this assay, from the lowest: compound 3; then compound 2; then compound 1.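

In this assay, 3-chloropyridin-4-yl in place of pyrazin-2-yl gives a 16-fold lower number from compound 2 to compound 3 (1.19 log units; beyond the scatter) and so shows that this place on the amide-type nitrogen can carry a much larger change than the first swap revealed. Against the 2-hydroxyphenyl group, the same change gives an 81-fold lower number from compound 1 to compound 3 (1.91 log units; beyond the scatter) and spans a wide range within one shared core. Nothing available explains the size of these steps.

The compounds shown cannot separate the part played by the chlorine from that of the ring itself. As far as these compounds go, how a plain pyridin-4-yl group, or a 3-fluoropyridin-4-yl or 3-methylpyridin-4-yl group, would compare remains open.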